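The compounds below may be only part of what the source reports. "The series", "measured", "known", "first", "only" and "open" are said of these compounds alone.

Working notes on the series. The shared core is that of compound 1 `Clc1[nH]ccc2ncnc1-2`. In a functional assay on EL4 cells (Mus musculus) for inhibition, tested at 100 uM (on this read-out higher numbers stand for more inhibition at the one concentration tested (going by the name of the read-out) and lower numbers for less inhibition), compound 1 gives only a limit of the assay, < 5%. Compound 2 `OC[C@H]1OC(n2cnc3c(Nc4ccccc4)nccc32)[C@H](O)[C@@H]1O` carries an anilino group on the core, and in this assay compound 2 gives 10%. Compound 3 `OC[C@H]1OC(n2cnc3c(S)nccc32)[C@H](O)[C@@H]1O` is the sulfanyl analogue. In this assay compound 3 gives only a limit of the assay, < 5%. Going by the values given here, the single measured step in the set, a number at least 5 percentage points lower from compound 2 to compound 3 (that floor lies within the scatter), runs into the limit of < 5% in this assay, at which 2 of the 3 values shown sit, and cannot be sized more closely than that.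

Among the compounds with values here, compound 3 therefore stands at the limit of this assay, as compound 1 does, while compound 2 is the only member of the set that returns a number. The next compound, compound 4 `CNc1nccc2c1ncn2C1O[C@H](CO)[C@@H](O)[C@H]1O`, differs from compound 3 by methylamino in place of sulfanyl on an aromatic carbon. Within the data shown here, no measured pair shares this exact change; the nearest comparison is the measured step above, which by its own size lies within the scatter. No shift beyond the scatter is therefore expected in this assay for compound 4, and the expected step is a number at least 1 percentage points higher from compound 3 to compound 4 (that floor lies within the scatter). Compound 4 is expected to give 6%, within 0% to 15%, with a good chance that only a limit is reported.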

Compound 4, a percentage reported as inhibition, at one concentration (the size of the read-out at that concentration, not a potency): 11%
For compound 4 the middle estimate is 5 percentage points below the measured one, and the stated range covers the measured number.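

At this position, on an aromatic carbon next to the ring nitrogen, methylamino in place of sulfanyl gives a number at least 6 percentage points higher from compound 3 to compound 4 (that floor lies within the scatter) in this assay, so the printed step from the sulfanyl compound now points upward, though its floor stays inside the scatter. Methyl in place of phenyl on the nitrogen gives a number 1 percentage points higher from compound 2 to compound 4 (within the scatter), which shows for the first time in the set that the phenyl ring of the anilino group can be replaced by methyl with no shift beyond the scatter in this read-out. The step from the sulfanyl compound cannot be sized more closely than its floor, and the only measured numbers remain those of the two nitrogen-linked compounds, with the rest of the set sitting at a limit: the limit of < 5% in this assay, at which 2 of the 4 values shown sit.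

On these data alone, whether any group on this carbon can move this assay clearly beyond the scatter remains open. Also open, as far as these compounds go, is what an unsubstituted amine, a longer alkyl chain on the nitrogen or a carboxylic acid would do at this position.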